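Fluoro in place of methoxy: working notes on the series

This account rests on a few compounds, and the source may have more. Where it says the series, first, only, none or still open, it means among the compounds named here.

Values in a functional assay on KB cells (Homo sapiens) for antiproliferative activity, read by sulforhodamine B assay, with a stated time of 3 days; on this read-out higher numbers stand for an effect only at larger amounts of compound and lower numbers for an effect already at smaller amounts:
- compound 1 `CCC1=C(O)c2c(oc(-c3ccc(C(C)C)cc3)cc2=O)C(CC)(CC)C1=O`: 8.13 uM
- compound 2 `CCC1=C(O)c2c(oc(-c3ccc(CBr)cc3)cc2=O)C(CC)(CC)C1=O`: > 46.5 uM (a limit, not a number)
- compound 3 `CCC1=C(O)c2c(oc(-c3ccc(OC)c(OC)c3)cc2=O)C(CC)(CC)C1=O`: 14.7 uM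

Compound 3, at 14.7 uM, lies within the scatter of compound 1, at 8.13 uM. Compound 4 `CCC1=C(O)c2c(oc(-c3ccc(OC)c(F)c3)cc2=O)C(CC)(CC)C1=O` has fluoro in place of methoxy on an aromatic carbon, ortho to a methoxy group and meta to a large group: fluoro in place of methoxy on an aromatic carbon.

For the measured compounds named here, no measured step covers this exchange. The only one, an at least 5.7-fold higher number from compound 1 to compound 2 (0.75 log units; beyond the scatter), is bromomethyl in place of isopropyl on an aromatic carbon, so it bears only loosely, as a sign that a single exchange on an aromatic carbon can move the number beyond the scatter. Its far end is a limit: the limit of > 46.5 uM in this assay, at which 1 of the 3 values shown sits.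

A step beyond the scatter is therefore possible, but none is expected in this assay, and no firm direction is expected either. The expected step is a 1.1-fold lower number from compound 3 to compound 4 (0.05 log units; within the scatter). For compound 4 the estimated value is 13 uM, with an expected range of 5.5 uM to 30 uM.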

Compound 4, concentration for half-maximal effect: 26.7 uM
Beside the measured number, compound 4's estimate is 2.1-fold (0.31 log units) below it, and the stated range covers the measured number.
By their numbers in this assay, from the lowest: compounds 1, 3 and 4 (each within the scatter of the next, the first and the last beyond it). At a limit, above all of these: compound 2.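

In this assay, fluoro in place of methoxy on this aromatic carbon, ortho to a methoxy group and meta to a large group, gives a 1.8-fold higher number from compound 3 to compound 4 (0.26 log units; within the scatter), so the methoxy group that leaves is not needed to keep the number within the scatter of compound 3. The exchange of the whole aryl group gives a 3.3-fold higher number from compound 1 to compound 4 (0.52 log units; beyond the scatter), a step beyond the scatter, although compound 3 lies within the scatter of both compound 1 and compound 4. The remaining step, an at least 1.7-fold lower number from compound 2 to compound 4 (0.24 log units; that floor lies within the scatter), has a far end that is compound 2's limit and not a number: the limit of > 46.5 uM in this assay, at which 1 of the 4 values shown sits.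

The compounds shown leave open whether chloro, hydroxy or an amine on this carbon would also stay within the scatter of compound 3. They also leave open how a plain hydrogen there would compare with fluoro and methoxy.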